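A few compounds are considered here, and "the series" means these few. Any claim that something is new, unique, unknown or untested is made for them only; others in the source may bear on it.

Of the compounds shown here, two have been measured in a functional assay for antagonist activity at Neuropeptides B/W receptor type 1 (Homo sapiens), read by cAMP accumulation; on this read-out higher numbers stand for weaker inhibition and lower numbers for stronger inhibition. Compound 1 `FC(F)(F)c1ccc2[nH]c(-c3ccccc3)nc2c1` carries a trifluoromethyl group on the shared core and an unsubstituted phenyl ring; in this assay compound 1 gives 1200 nM. Compound 2 `CC(=O)c1cccc(-c2nc3cc([N+](=O)[O-])ccc3[nH]2)c1` carries a nitro group on the core and an acetyl group on the phenyl ring. For compound 2 this assay reports only a limit, > 31600 nM, so its true potency is not known beyond that boundary; it stands at the limit of > 31600 nM in this assay, at which 1 of the 2 values shown sits. Among the compounds with values here, no measured step between compounds that differ in a single place is available, so the gap between compound 1 and compound 2 can only be read as two separate values with more than one difference between them.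

Compound 3 `O=[N+]([O-])c1ccc2[nH]c(-c3cccc(Cl)c3)nc2c1` keeps the nitro group on the core and differs from compound 2 by chloro in place of acetyl on an aromatic carbon. The step from compound 2 to compound 3 in this assay is expected to be an at least 3.1-fold lower number from compound 2 to compound 3 (0.49 log units; beyond the scatter), toward stronger inhibition, though starting from a limit the size is uncertain. Compound 3 is estimated at 10000 nM, within a range from 2000 nM to 40000 nM.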

Compound 3, half-maximal inhibitory concentration: 9980 nM
Compound 3: the middle estimate sits 1.0-fold (0.00 log units) above what was measured, within the range that was stated.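

Compounds 2 and 3 provide the first comparison across a single change. With the nitro group kept on the core, chloro in place of acetyl on the aromatic carbon meta to a large group gives an at least 3.1-fold lower number from compound 2 to compound 3 (0.50 log units; beyond the scatter) in this assay. Compound 2 is reported only as a limit, so the step gives a direction and a minimum size, but not its full size: the limit of > 31600 nM in this assay, at which 1 of the 3 values shown sits. Acetyl brings 3 heavy atoms and 1 hydrogen-bond acceptor, while chloro brings 1 heavy atom and no hydrogen-bond acceptor, and of these two nitro compounds, only the one with chloro has a value that can be read as an actual number.

This pair cannot tell whether the difference comes from losing acetyl or from adding chloro, and an otherwise identical compound with a plain hydrogen, a methoxy group or an amine at this place would help to separate the two. As far as these compounds go, compound 1 differs from compound 3 in more than one place, so it also remains open whether chloro would have a similar effect on a core bearing trifluoromethyl instead of nitro.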